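The source may report more compounds than this note shows. Statements on the series, on what has been measured and on what is new or still open speak of the compounds shown alone.

Measured compounds:
Compound 1 `CN(Cc1ccccc1)C(=O)C1CCN(C(=O)c2ccc(S(C)(=O)=O)c([N+](=O)[O-])c2)CC1`. In an assay on isolated protein for inhibition of thyroid hormone receptor beta (Homo sapiens), read by fluorescence polarization (a higher number here means a weaker inhibitor, a lower number a stronger inhibitor), compound 1 gives > 60000 nM, a limit of the assay.
Compound 2 `CN(Cc1ccccc1F)C(=O)C1CCN(C(=O)c2ccc(S(C)(=O)=O)c([N+](=O)[O-])c2)CC1`. In this assay compound 2 gives > 60000 nM, again a limit of the assay.

Among the measured compounds shown here, the only measured step, a step that the two limits leave unreadable from compound 1 to compound 2, cannot be read because the limit of > 60000 nM in this assay, at which 2 of the 2 values shown sit, applies to both values. Compound 2 thus stands only at a limit. Compound 3 `CC1Cc2ccccc2N1C(=O)C1CCN(C(=O)c2ccc(S(C)(=O)=O)c([N+](=O)[O-])c2)CC1` differs by 2-methyl-2,3-dihydro-1H-indol-1-yl in place of (2-fluorobenzyl)(methyl)amino on a carbonyl carbon. For the measured compounds named here, no measured step bears on this change, so no step beyond the scatter is expected; the estimated step is a number no higher from compound 2 to compound 3 (the limit leaves the size open). Compound 3 is expected at 60000 nM, within 8000 nM to 200000 nM.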

Compound 3, half-maximal inhibitory concentration: > 60000 nM
Compound 3 was reported as a limit (the forecaster's own chance of this, stated with the estimate: 70%); the middle value lies on the limit itself.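

Among the compounds shown here, no step among compound 1, compound 2 and compound 3 can be read, because all three share one limit: the limit of > 60000 nM in this assay, at which 3 of the 3 values shown sit. The compounds shown leave open whether either change affects inhibition in this assay, and what on the shared core would give a measurable value.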